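Swapping a Nitro Group for a Methoxy Group

This account rests on a few compounds, and the source may have more. Where it says the series, first, only, none or still open, it means among the compounds named here.

Of the compounds shown here, three have been tested in an ADME assay on HepG2 cells (Homo sapiens) for cytotoxicity, read by MTT assay, with a stated time of 48 h; a higher number here means that more compound is tolerated, a lower number that less compound is tolerated. Compound 1 `C#CCN(c1nc(-c2cccc(Br)c2)no1)C1CCCCC1` gives 53.5 ug/mL, and compound 2 `CC(=O)OC[C@H]1O[C@H](OC[C@H](Cn2cc(COc3ccc(-c4noc(NC5CCCCC5)n4)cc3)nn2)OC(C)=O)C=C[C@@H]1OC(C)=O` gives 99.5 ug/mL. Compound 3 `CC(=O)OC[C@H]1O[C@H](OC[C@@H](Cn2cc(CN(c3nc(-c4cccc([N+](=O)[O-])c4)no3)C3CCCCC3)nn2)OC(C)=O)C=C[C@@H]1OC(C)=O` yields only a limit in this assay, > 200 ug/mL, that is the limit of > 200 ug/mL in this assay, at which 1 of the 3 values shown sits.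

Compound 4 `COc1ccc(-c2noc(N(Cc3cn(C[C@H](CO[C@@H]4C=C[C@H](OC(C)=O)[C@@H](COC(C)=O)O4)OC(C)=O)nn3)C3CCCCC3)n2)cc1` awaits measurement. It differs from compound 3 by 4-methoxyphenyl in place of 3-nitrophenyl on an aromatic carbon. Within the data shown here, no measured pair isolates this exact change, so its effect cannot be read from the numbers; all three values show that such compounds are tolerated at fairly high amounts. The step from compound 3 to compound 4 is expected to be an at least 1.3-fold lower number from compound 3 to compound 4 (0.12 log units; that floor lies within the scatter), a modest move toward less compound tolerated, possibly not beyond the scatter. Compound 4 is estimated at 150 ug/mL, within 60 ug/mL to 300 ug/mL.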

Compound 4, half-maximal cytotoxic concentration: 141 ug/mL
Beside the measured number, compound 4's estimate is 1.1-fold (0.03 log units) above it, and the stated range covers the measured number.
By their numbers in this assay, from the lowest: compounds 1, 2 and 4 (each within the scatter of the next, the first and the last beyond it). At a limit, above all of these: compound 3.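

In this assay, among these compounds, the first change that can be read at this position, 4-methoxyphenyl in place of 3-nitrophenyl, gives an at least 1.4-fold lower number from compound 3 to compound 4 (0.15 log units; that floor lies within the scatter). On these data alone, compound 3 stands at a limit and not at a number, so the true size of this step stays unknown: the limit of > 200 ug/mL in this assay, at which 1 of the 4 values shown sits. Compound 4 now gives this position a measured number against which other groups can be compared.

As far as these compounds go, whether the step comes from the group itself or from where it sits on the phenyl ring stays open. So does how 3-methoxyphenyl, or a phenyl ring carrying an amine or a carboxylic acid, would compare.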